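Halogenated Aryl Ureas on a Shared Chloropyrazine Core

The source may hold more compounds than are shown below. What is called first, only, known or untested is meant among the compounds shown, and "the series" means these compounds.

Measured so far:
Compound 1, `Cc1ccc(NC(=O)Nc2cccc(CNc3nccnc3Cl)c2)c(C)c1`, 9230 nM
Compound 2, `O=C(Nc1ccc(C(F)(F)F)cc1)Nc1cccc(CNc2nccnc2Cl)c1`, 4580 nM

Both compounds were tested in a functional assay on T-24 cells (Homo sapiens) for antiproliferative activity, read by MTT assay, with a stated time of 48 h; a higher number here means a weaker inhibitor, a lower number a stronger inhibitor. Compound 1 and compound 2 give numbers that lie within the usual scatter of each other, so neither can be called the stronger inhibitor on these two values alone. Compound 3, `O=C(Nc1cccc(CNc2nccnc2Cl)c1)Nc1ccc(Cl)cc1Br`, has not yet been measured. It differs from compound 1 in one place: 2-bromo-4-chlorophenyl in place of 2,4-dimethylphenyl on an amide-type nitrogen. Among the compounds with values here, no step between measured compounds matches this change, so there is no direct guide to its size. The expectation is a small step from compound 1 to compound 3, likely toward a lower number, but one that may well stay within the scatter; this expected step is a 1.7-fold lower number from compound 1 to compound 3 (0.22 log units; within the scatter). Compound 3 is therefore estimated to give 5500 nM, with a range from 2000 nM to 15000 nM.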

Compound 3, half-maximal inhibitory concentration: 6650 nM
Compound 3: the middle estimate sits 1.2-fold (0.08 log units) below what was measured; the range from low to high includes it.
By their numbers in this assay, from the lowest: compounds 2, 3 and 1 (each within the scatter of the next).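

In this assay, within the data shown here, replacing 2,4-dimethylphenyl with 2-bromo-4-chlorophenyl on the amide-type nitrogen gives a 1.4-fold lower number from compound 1 to compound 3 (0.14 log units; within the scatter) as the only direct reading of this change. An aryl group carrying one chlorine and one bromine therefore cannot be told apart from the carbon-only 2,4-dimethylphenyl group at this position, so this exchange neither clearly helps nor clearly harms antiproliferative activity. Nothing measured here speaks to why the two groups read alike.

As far as these compounds go, whether this position can move the number beyond the scatter remains open, and a ring bearing an amine or a carboxylic acid, or a saturated cyclohexyl group, on the same nitrogen would test that. The shared core is also identical in all three compounds, so its own contribution cannot be read.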